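Bromo to Iodo on the Aryl Ring of Compound 1

This account rests on a few compounds, and the source may have more. Where it says the series, first, only, none or still open, it means among the compounds named here.

For the measured compounds named here, the two compounds measured so far were tested in an assay on HEK293 cells for displacement of a labelled ligand from Neuronal acetylcholine receptor; alpha3/beta4 (Homo sapiens), read by radioligand binding, with a stated time of 5 min; a higher number here means a weaker inhibitor, a lower number a stronger inhibitor. Compound 1, `Brc1cccc(C2=NCCCC2)c1`, gives 29.8 nM in this assay. Going by the values given here, compound 2, `Brc1cc(Br)cc(C2=NCCCC2)c1`, gives 70.8 nM in this assay, and the single step recorded, a 2.4-fold higher number from compound 1 to compound 2 (0.38 log units; beyond the scatter), is a change of bromo in place of hydrogen on an aromatic carbon. Compound 1 therefore stands with the lowest of the two numbers shown; its nearest neighbour is compound 2, and the gap between them lies beyond the scatter.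

The next compound, compound 3, `Ic1cccc(C2=NCCCC2)c1`, has not yet been measured. Its difference from compound 1 is iodo in place of bromo on an aromatic carbon. Among the compounds with values here, no measured step bears on this halogen swap: the only step recorded adds a second bromo rather than exchanging one halogen for another, so it gives no direction for the change. Compound 3 is therefore expected to sit close to compound 1, with a step of a 1.2-fold lower number from compound 1 to compound 3 (0.08 log units; within the scatter) that is expected to stay within the scatter. The estimate for compound 3 in this assay is 25 nM, with a range from 9 nM to 70 nM.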

Compound 3, inhibition constant: 4.7 nM
Beside the measured number, compound 3's estimate is 5.3-fold (0.73 log units) above it; the whole stated range lies above it.
By their numbers in this assay, from the lowest: compound 3; then compound 1; then compound 2.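

At this aromatic carbon, meta to a group of 6 heavy atoms, the identity of the halogen matters in this assay: the exchange of bromo for iodo gives (a 6.3-fold lower number from compound 1 to compound 3 (0.80 log units; beyond the scatter)), whereas the earlier compounds had shown only what adding a second bromo does. That addition moved the number the other way (a 2.4-fold higher number from compound 1 to compound 2 (0.38 log units; beyond the scatter)), so the two single changes made to compound 1 run in opposite directions, and the stronger binding comes from a swap of one heavy atom for another that leaves the counts of rings, hydrogen-bond donors and acceptors and the net charge as they were. No measurement available here accounts for the effect of iodo.

The compounds shown leave open where chloro or fluoro at this aromatic carbon would fall relative to bromo and iodo, and whether a group that is not a halogen, such as methoxy or nitrile, could keep the number as low as compound 3 does. From the compounds shown here alone, it also remains open whether a second iodo would raise the number as the second bromo did.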